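A few compounds are considered here, and "the series" means these few. Any claim that something is new, unique, unknown or untested is made for them only; others in the source may bear on it.

Measured:
compound 1 `COc1ccccc1C(=O)NCc1ccc(CNS(=O)(=O)c2cccc(Cl)c2)cc1` — 1000 nM
compound 2 `COc1ccccc1C(=O)NCc1ccc(CNS(=O)(=O)c2ccc(Cl)cc2)cc1` — 1000 nM
compound 3 `COc1ccccc1C(=O)NCc1ccc(CNS(=O)(=O)c2ccc([N+](=O)[O-])cc2)cc1` — 100 nM

In an assay on MDA-MB-231 cells for displacement of a labelled ligand from C-X-C chemokine receptor type 4 (Homo sapiens), read by fluorescence and microscopy, with stated times of 10 min and 30 min (a lower number here means that less compound is needed, a higher number that more compound is needed for the effect), compound 1 gives 1000 nM, level with compound 2, and the two together are the highest of the three numbers; the step of no change at the digits printed from compound 1 to compound 2 (within the scatter) stays within the scatter. Compound 3 stands apart from both: a 10-fold lower number from compound 1 to compound 3 (1.00 log units; beyond the scatter) and a 10-fold lower number from compound 2 to compound 3 (1.00 log units; beyond the scatter) are each beyond the scatter. Going by the values given here, every measured step sits on the aryl group attached to the sulfonyl sulfur; nothing measured so far touches the (2-methoxyphenyl)carbonyl end of the shared core.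

Compound 4 `Cc1ccccc1C(=O)NCc1ccc(CNS(=O)(=O)c2cccc(Cl)c2)cc1` differs from compound 1 at exactly that untouched end: methyl in place of methoxy on an aromatic carbon. Among the compounds with values here, no measured step bears on this change, so there is no footing for expecting a shift beyond the scatter in either direction. The estimate is therefore carried over from compound 1, with the range widened to reflect an untested change. Compound 4 is expected to give 1000 nM, within a range from 350 nM to 3000 nM. The expected step is no change at the digits printed from compound 1 to compound 4 (within the scatter).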

Compound 4, effective concentration (reported as EC, without a stated level of effect): 100 nM
Estimate against measurement, compound 4: 10-fold (1.00 log units) above; measured number below the stated range.
By their numbers in this assay, from the lowest: compounds 3 and 4 (each within the scatter of the next); then compounds 1 and 2 (each within the scatter of the next).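

In this assay, methyl in place of methoxy on the aromatic carbon ortho to a large group gives a 10-fold lower number from compound 1 to compound 4 (1.00 log units; beyond the scatter). Going by these compounds alone, the end of the shared core carrying the (2-methoxyphenyl)carbonyl group therefore responds to substitution, and the aryl group on the sulfonyl sulfur is no longer the only place where the number moves; the step there to 4-nitrophenyl gives a 10-fold lower number from compound 1 to compound 3 (1.00 log units; beyond the scatter). No measurement available here accounts for the shift at this position.

From the compounds shown here alone, it remains open whether the 2-methylphenyl gain holds with the 4-chlorophenyl or 4-nitrophenyl group on the sulfonyl sulfur, and whether the two changes would add in one compound. Also open, going by these compounds, is how an ethyl group, a chlorine atom or an amine in the same place would compare with methyl and methoxy.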